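This account rests on a few compounds, and the source may have more. Where it says the series, first, only, none or still open, it means among the compounds named here.

Compound 1 `CCc1ccccc1-c1n[nH]c(-c2cccc(OC)c2)n1` and compound 2 `COc1ccc(-c2n[nH]c(-c3ccccc3)n2)c(C)c1` share a core, but how their cores differ is not broken down here. In a functional assay on the whole organism (Cricetulus griseus) with Cricetinae gen. sp. as the target (on this read-out lower numbers stand for an effect already at smaller amounts and higher numbers for an effect only at larger amounts of compound), compound 1 gives 0.04 mg/kg. For compound 2 this assay reports only a limit, (the limit of > 10 mg/kg in this assay, at which 1 of the 3 values shown sits), and compound 2 gives > 10 mg/kg. Compound 3 `COc1cccc(-c2nc(-c3ccc(OC)cc3C)n[nH]2)c1` arises from compound 2 by the change (methoxy in place of hydrogen on an aromatic carbon); in this assay compound 3 gives 0.2 mg/kg, a step of an at least 50-fold lower number from compound 2 to compound 3 (1.69 log units; beyond the scatter). Compound 4 `CCc1ccccc1-c1n[nH]c(-c2cc(OC)cc(OC)c2)n1` arises from compound 1 by the same kind of change, (methoxy in place of hydrogen on an aromatic carbon), though here the place is also meta to a methoxy group, which is not so in compound 2. A smaller step is expected for compound 4, since compound 1 already carries a methoxy group and gives 0.04 mg/kg. The expected step is a 1.3-fold higher number from compound 1 to compound 4 (0.10 log units; within the scatter). The estimate for compound 4 is 0.05 mg/kg, between 0.01 mg/kg and 0.3 mg/kg.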

Compound 4, dose for half-maximal effect: 10 mg/kg
The estimate for compound 4 lay 200-fold (2.30 log units) below the measured number; measured number above the stated range.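

In this assay, methoxy in place of hydrogen gives a 250-fold higher number from compound 1 to compound 4 (2.40 log units; beyond the scatter), so the change that lowered the number on the core of compound 2 does not carry over to the core of compound 1: the same change on two cores in this assay, an at least 50-fold lower number (1.69 log units; beyond the scatter) from compound 2 to compound 3 and a 250-fold higher number (2.40 log units; beyond the scatter) from compound 1 to compound 4, at least 12000-fold (4.09 log units) apart, beyond the scatter of two such steps Compound 2 is known only by a limit: the limit of > 10 mg/kg in this assay, at which 1 of the 4 values shown sits. This is one pair on each core, and the new group is meta to a methoxy group only in compound 4, so the data cannot separate the effect of the core from that of the place, and they do not show why the steps differ.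

Still open, on these data alone, is whether another methoxy group elsewhere on the ring of compound 1 would raise the number as much. Also open, as far as these compounds go, is what a different group in the same place, such as an amine or a hydroxyl, would do.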